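The source may report more compounds than this note shows. Statements on the series, on what has been measured and on what is new or still open speak of the compounds shown alone.

Compound 1, `CC(C)c1n[nH]c2c(NCc3ccc(-c4ccccn4)cc3)nc(SCC3CNC(=O)O3)nc12`, gives 80 nM in a functional assay on HT cells (Homo sapiens) for antiproliferative activity, read by fluorescence, with a stated time of 72 h; on this read-out lower numbers stand for stronger inhibition of growth and higher numbers for weaker inhibition of growth.
Compound 2, `CC(O)CSc1nc(NCc2ccc(-c3ccccn3)cc2)c2[nH]nc(C(C)C)c2n1`, gives 62 nM in this assay.
Compound 3, `CSc1nc(NCc2ccc(-c3ccccn3)cc2)c2[nH]nc(C(C)C)c2n1`, gives 783 nM in this assay.

Compound 3 stands highest of the three numbers, so it is the weakest inhibitor of growth among them. Compound 4, `CC(C)c1n[nH]c2c(NCc3ccc(-c4ccccn4)cc3)nc(SC[C@H](O)CN)nc12`, differs from compound 3 in one place: 2-amino-1-hydroxyethyl in place of hydrogen on a saturated chain carbon bound to a sulfur. Going by the values given here, two measured steps bear on this change, each replacing a group on the same saturated chain carbon bound to a sulfur with hydrogen: a 9.8-fold higher number from compound 1 to compound 3 (0.99 log units; beyond the scatter) and a 13-fold higher number from compound 2 to compound 3 (1.10 log units; beyond the scatter). Both show that a group at this place goes with a much lower number, and the 2-amino-1-hydroxyethyl entering compound 4 resembles the 1-hydroxyethyl of compound 2. A large fall in the number is therefore expected in this assay, an 11-fold lower number from compound 3 to compound 4 (1.05 log units; beyond the scatter). Compound 4 is estimated at 70 nM, within a range from 30 nM to 180 nM.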

Compound 4, concentration for 50% growth inhibition: 63 nM
The estimate for compound 4 lay 1.1-fold (0.05 log units) above the measured number, within the range that was stated.
By their numbers in this assay, from the lowest: compounds 2, 4 and 1 (each within the scatter of the next); then compound 3.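

In this assay, the 2-amino-1-hydroxyethyl group brings a large change (a 12-fold lower number from compound 3 to compound 4 (1.09 log units; beyond the scatter)), so a third group on this saturated chain carbon bound to a sulfur goes with a much lower number than hydrogen. The steps to the other two groups ((a 1.0-fold higher number from compound 2 to compound 4 (0.01 log units; within the scatter)) and (a 1.3-fold lower number from compound 1 to compound 4 (0.10 log units; within the scatter))) lie within the scatter, so compound 1, compound 2 and compound 4 cannot be told apart here. Open questions are how a carboxylic acid, a longer chain or a 2-aminoethyl group without the hydroxyl would compare, and how the opposite stereocentre would fare. Nothing available explains these results.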